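Aromatic halogen substitution and whole-organism inhibition: compound 4

The source may report more compounds than this note shows. Statements on the series, on what has been measured and on what is new or still open speak of the compounds shown alone.

Measured compounds:
compound 1 `C/N=C(\S)n1nc(-c2ccccc2)nc1N` 54%
compound 2 `C/N=C(\S)n1nc(-c2cccc(Cl)c2)nc1N` 54%
compound 3 `C/N=C(\S)n1nc(-c2ccccc2Cl)nc1N` 18%

In a functional assay on the whole organism for inhibition, with Rattus norvegicus as the target, at a dose of 30 mg/kg (on this read-out lower numbers stand for less inhibition and higher numbers for more inhibition at the one dose given (going by the name of the read-out)), compound 1 gives 54%, level with compound 2 and together with it the highest of the three numbers. The two measured steps from compound 1 both put chloro in place of hydrogen on an aromatic carbon but end differently: no change at the digits printed from compound 1 to compound 2 (within the scatter), whereas a number 36 percentage points lower from compound 1 to compound 3 (beyond the scatter). Where a halogen enters the six-membered aromatic ring of carbon only therefore decides the outcome, on the evidence of compounds 2 and 3.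

Compound 4 `C/N=C(\S)n1nc(-c2ccc(Br)cc2)nc1N` is not yet measured. Its change from compound 1 is bromo in place of hydrogen on an aromatic carbon, with the bromo para to a large group. For the measured compounds named here, no measured step covers bromo, and none covers this place on the ring, so the two chloro steps bear on it only loosely: one was within the scatter, the other a large drop. With no drop shown for a halogen at a place other than that of compound 3, compound 4 is expected to stay near compound 1, with a step of a number 4 percentage points lower from compound 1 to compound 4 (within the scatter). The estimate for compound 4 is 50%, in a range from 28% to 70%.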

Compound 4, a percentage reported as inhibition, in the whole organism at one dose (the size of the read-out at that dose, not a potency): 88%
Compound 4: middle estimate off by 38 percentage points, on the low side; the whole stated range lies below it.
By their numbers in this assay, from the lowest: compound 3; then compounds 1 and 2 (each within the scatter of the next); then compound 4.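

In this assay the series now holds a step upward, a number 34 percentage points higher from compound 1 to compound 4 (beyond the scatter) with bromo in place of hydrogen on an aromatic carbon, para to a large group. The chloro steps gave no change at the digits printed from compound 1 to compound 2 (within the scatter) and a number 36 percentage points lower from compound 1 to compound 3 (beyond the scatter) and neither went upward, so a halogen on this six-membered aromatic ring can raise the number as well as leave it level or lower it. No measurement at hand speaks to the reason for this rise.

The compounds shown leave open whether the rise belongs to bromo itself or to its place on the ring, since the step to compound 4 differs from both chloro steps in the halogen and in the place together. They also leave open how a group other than a halogen, such as an amine, a carboxylic acid or a longer chain, would read at the same place, para to a large group.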